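The source may report more compounds than this note shows. Statements on the series, on what has been measured and on what is new or still open speak of the compounds shown alone.

In a functional assay on K562 cells (Homo sapiens), read by MTT assay, with a stated time of 72 h (on this read-out lower numbers stand for stronger inhibition and higher numbers for weaker inhibition), compound 2, `COc1ncnc2c1c(I)cn2[C@@H]1O[C@H](CO)[C@@H](O)[C@H]1O`, gives only a limit, > 20000 nM, so it sits at the limit of > 20000 nM in this assay, at which 1 of the 2 values shown sits. Compound 1, `Nc1nc(N)c2c(-c3cc4ccccc4o3)cn([C@@H]3O[C@H](CO)[C@@H](O)[C@H]3O)c2n1`, gives 18600 nM in this assay, also a weak result. Compound 3, `COc1ncnc2c1c(-c1ccco1)cn2[C@@H]1O[C@H](CO)[C@@H](O)[C@H]1O`, is not yet measured; it differs from compound 2 by furan-2-yl in place of iodo on an aromatic carbon. Among the measured compounds shown here, no measured step shows what this change does. Because compound 1 gives 18600 nM, the series looks weak throughout. The step that the limit leaves unreadable from compound 2 to compound 3 is expected to stay within the scatter. Compound 3 is therefore expected at 25000 nM, between 8000 nM and 80000 nM.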

Compound 3, half-maximal inhibitory concentration: 60 nM
For compound 3 the middle estimate is 420-fold (2.62 log units) above the measured one; the whole stated range lies above it.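

In this assay, furan-2-yl in place of iodo on this aromatic carbon gives an at least 330-fold lower number from compound 2 to compound 3 (2.52 log units; beyond the scatter). Among the compounds shown here, this shows that the group at this one position can separate a weak compound from a strong one, something the earlier compounds could not show, as no measured pair differed in one place. The true size of the step stays unknown because compound 2 gives only a limit: the limit of > 20000 nM in this assay, at which 1 of the 3 values shown sits.

From the compounds shown here alone, what a phenyl ring or an amine would give at this carbon stays open. So does whether the furan oxygen matters, a question that a thiophen-2-yl group could address.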